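Propoxy in Place of Methylamino on the Shared Core

The source may hold more compounds than are shown below. What is called first, only, known or untested is meant among the compounds shown, and "the series" means these compounds.

Compound 1 `CNc1nc(N)nc2c1ncn2/C=C1/CC1(CO)CO` gives 67000 nM in an ADME assay on BCBL1 cells (Homo sapiens) for cytotoxicity, with a stated time of 7 days; on this read-out higher numbers stand for lower toxicity in this test and lower numbers for higher toxicity in this test.
Compound 2 `Nc1nc(NCc2ccccc2)c2ncn(/C=C3/CC3(CO)CO)c2n1` gives 19900 nM in this assay.
Compound 3 `CSc1nc(N)nc2c1ncn2/C=C1/CC1(CO)CO` gives only a limit, > 20000 nM, in this assay.

Compound 1 stands highest of the two numbers in this assay; its nearest neighbour is compound 2, with a 3.4-fold lower number from compound 1 to compound 2 (0.53 log units; beyond the scatter). The value of compound 3 is a limit, not a number, so the step from compound 1 to compound 3 is a step that the limit leaves unreadable from compound 1 to compound 3, and that from compound 2 to compound 3 is a number no lower from compound 2 to compound 3 (the limit leaves the size open).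

Compound 4 `CCCOc1nc(N)nc2c1ncn2/C=C1/CC1(CO)CO` differs from compound 1 in one place: propoxy in place of methylamino on an aromatic carbon. For the measured compounds named here, the closest measured step is the one from compound 1 to compound 3, which also exchanges the methylamino group for another on the same carbon, yet it stays unreadable; the one readable step, from compound 1 to compound 2, changes a different position and was modest. With nothing readable at the relevant position, the expectation for compound 4 in this assay is a step no larger than the scatter, a 1.3-fold lower number from compound 1 to compound 4 (0.13 log units; within the scatter), with a fair chance that only a limit is reported. Compound 4 is therefore estimated at 50000 nM, within a range from 15000 nM to 150000 nM.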

Compound 4, half-maximal cytotoxic concentration: > 20000 nM
Compound 4 was reported as a limit (the forecaster's own chance of this, stated with the estimate: 30%); the middle value does not contradict the limit.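

With propoxy in place of methylamino, compound 4 gives no number in this assay, and its value is a limit, the same one compound 3 gives, so a second replacement of the methylamino group on this aromatic carbon also ends at a limit: the limit of > 20000 nM in this assay, at which 2 of the 4 values shown sit.

Against benzylamino, the change to propoxy can be read in direction only: a number no lower from compound 2 to compound 4 (the limit leaves the size open). The steps from compound 1 and from compound 3 to compound 4 cannot be read.

From the compounds shown here alone, how far compound 3 and compound 4 lie from compound 1 remains open, as does whether those two differ from each other. Also open, going by these compounds, is what a longer alkoxy chain such as butoxy, or a carboxylic acid, on the same aromatic carbon would give in this assay.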